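Notes on compound 4, a variant of compound 1

This account rests on a few compounds, and the source may have more. Where it says the series, first, only, none or still open, it means among the compounds named here.

Measured compounds
Compound 1 `O=C1CC(c2nc(-c3cccc(Cl)c3)no2)CN1c1ccc(Cl)c(Cl)c1` gives 460 nM in an in vitro functional assay on HEK293-A cells for positive allosteric modulation of metabotropic glutamate receptor 5 (Homo sapiens), read by FLIPR and calcium flux; on this read-out higher numbers stand for an effect only at larger amounts of compound and lower numbers for an effect already at smaller amounts.
Compound 2 `O=C1CC(c2nc(-c3cccc(Cl)c3)no2)CN1c1ccccc1Cl` reaches only a limit of this assay, > 10000 nM.
Compound 3 `Cc1cccc(N2CC(c3nc(-c4cccc(Cl)c4)no3)CC2=O)c1` likewise reaches only a limit of this assay, > 10000 nM.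

Among the measured compounds shown here, compound 1 stands as the only true number in the set; the other two values sit at the limit of > 10000 nM in this assay, at which 2 of the 3 values shown sit. Both measured steps change the aryl on the amide-type nitrogen in the ring: an at least 21-fold higher number from compound 1 to compound 2 (1.33 log units; beyond the scatter) and an at least 21-fold higher number from compound 1 to compound 3 (1.33 log units; beyond the scatter). The pair compound 2 and compound 3 shows only two limits, and so a step that the two limits leave unreadable from compound 2 to compound 3.

Compound 4 `O=C1CC(c2nc(-c3ccc(F)cc3)no2)CN1c1ccc(Cl)c(Cl)c1` differs from compound 1 at another position: 4-fluorophenyl in place of 3-chlorophenyl on an aromatic carbon. For the measured compounds named here, no measured step touches this position, so nothing measured bears directly on the change. Going by the values given here, the measured steps show only that replacing an aryl group can move the number far. For compound 4 a loss rather than a gain is expected, and a moderate one is estimated: a 3.3-fold higher number from compound 1 to compound 4 (0.51 log units; beyond the scatter). Compound 4 is therefore expected to give 1500 nM in this assay, within a range from 400 nM to 8000 nM.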

Compound 4, half-maximal effective concentration: 2300 nM
Compound 4: the middle estimate sits 1.5-fold (0.19 log units) below what was measured, and the stated range covers the measured number.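

In this assay the aryl on the aromatic carbon between two ring nitrogen atoms proves to be a second position that affects the read-out, with 4-fluorophenyl in place of 3-chlorophenyl giving a 5.0-fold higher number from compound 1 to compound 4 (0.70 log units; beyond the scatter). Among the compounds shown here, the earlier steps changed only the aryl on the amide-type nitrogen, so this is the first reading of the opposite end of the shared core, and compound 4 gives a true number rather than a limit of the assay. The two groups match in heavy-atom count and in their counts of hydrogen-bond donors and acceptors, yet they differ in both the halogen and its place on the phenyl ring, and this single step does not separate those two differences.

Nothing shown accounts for the size of this step. Still open, as far as these compounds go, are how 3-fluorophenyl, 4-chlorophenyl and unsubstituted phenyl would read at this position, which would separate the halogen from its place, and whether a phenyl bearing an amine or a carboxylic acid would keep a true number in this assay.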